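This account rests on a few compounds, and the source may have more. Where it says the series, first, only, none or still open, it means among the compounds named here.

Working notes on the series.

Compound 2 `O=c1cc(CSC(=S)N2CCCCC2)oc2ccccc12` is the unsubstituted member of the shared core and in a functional assay on HEp-2 cells (Homo sapiens) for antiproliferative activity, read by MTT assay, with a stated time of 72 h (on this read-out lower numbers stand for stronger inhibition and higher numbers for weaker inhibition), compound 2 gives 12000 nM, the highest number among the three measured compounds. Compound 1 `O=c1cc(CSC(=S)N2CCCCC2)oc2cc(Cl)ccc12` gives 1600 nM in this assay, and compound 3 `COc1ccc2oc(CSC(=S)N3CCCCC3)cc(=O)c2c1` gives 1500 nM. The two measured steps both concern the aromatic part of the core: a 7.5-fold higher number from compound 1 to compound 2 (0.88 log units; beyond the scatter) and an 8.0-fold lower number from compound 2 to compound 3 (0.90 log units; beyond the scatter). Both lie beyond the scatter and are of similar size, in opposite directions.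

Compound 4 `O=c1cc(CSC(=S)N2CCOCC2)oc2ccccc12` is the next member, differing from compound 2 by morpholin-4-yl in place of piperidin-1-yl on a thiocarbonyl carbon. For the measured compounds named here, neither measured step touches this position; both alter the aromatic ring and leave the thiocarbonyl side chain untouched, so no measured step bears on this change and there is no measured pair to set its size or direction. For compound 4 the step is therefore expected to stay within the scatter of compound 2, as a 1.3-fold higher number from compound 2 to compound 4 (0.10 log units; within the scatter). Compound 4 is thus estimated at 15000 nM in this assay, with a range of 5000 nM to 45000 nM.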

Compound 4, half-maximal inhibitory concentration: > 25000 nM
Compound 4 ended at the assay's limit (the forecaster's own chance of this, stated with the estimate: 15%); middle value at least 1.6-fold (0.22 log units) away from the limit.
By their numbers in this assay, from the lowest: compounds 3 and 1 (each within the scatter of the next); then compound 2. At a limit, above all of these: compound 4.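

The thiocarbonyl side chain now has a measured step of its own: in this assay, an at least 2.0-fold higher number from compound 2 to compound 4 (0.31 log units; beyond the scatter), with morpholin-4-yl in place of piperidin-1-yl on a thiocarbonyl carbon. For the compounds shown here, the earlier steps changed only the aromatic part of the core, so this is the first indication that the number also responds to the ring on this carbon, and that here the change goes towards weaker inhibition. The value of compound 4 is a limit of the assay and not a number, so the direction of the step can be read but not its full size: the limit of > 25000 nM in this assay, at which 1 of the 4 values shown sits.

From the compounds shown here alone, whether this step carries over to the chloro and methoxy members of the core remains open. Also open, going by these compounds, is how a piperazin-1-yl ring or an open-chain diethylamino group would compare with piperidin-1-yl on the same carbon.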